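Ester capping of the acid tail in a biaryl amide series

This account rests on a few compounds, and the source may have more. Where it says the series, first, only, none or still open, it means among the compounds named here.

Measured so far:
Compound 1 `CC(C)N(Cc1cccc(OCCCCCC(=O)O)c1)C(=O)c1ccc(-c2cccc(Oc3ccccc3)c2)cc1` sits at a limit in an ADME assay on HepG2 cells (Homo sapiens) for cytotoxicity, read by CellTiter-Glo and resazurin assay, with a stated time of 72 h (a lower number here means that less compound is needed, a higher number that more compound is needed for the effect), reported as > 18700 nM.
Compound 2 `CC(C)N(Cc1cccc(OCCCCCC(=O)O)c1)C(=O)c1ccc(-c2cccc(F)c2)cc1` sits at a limit in this assay, reported as > 26000 nM.

Compound 1 stands only as a limit in this assay, and compound 2 does too, so the step that the two limits leave unreadable from compound 1 to compound 2 cannot be read, as the limit of > 18700 nM in this assay, at which 1 of the 2 values shown sits, and the limit of > 26000 nM in this assay, at which 1 of the 2 values shown sits, show. Compound 3 `CCOC(=O)CCCCCOc1cccc(CN(C(=O)c2ccc(-c3cccc(Oc4ccccc4)c3)cc2)C(C)C)c1` differs from compound 1 by ethyl in place of hydrogen on an oxygen next to a carbonyl group. Among the measured compounds shown here, no measured step bears on this change, and both measured compounds sit at limits, so no step beyond the scatter is expected. Compound 3 is expected to remain at a limit in this assay, an expected step that the limit leaves unreadable from compound 1 to compound 3. The estimate for compound 3 is 30000 nM, within 10000 nM to 100000 nM.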

Compound 3, half-maximal effective concentration: > 26000 nM
Compound 3: only a limit was reported; the forecaster's own chance of this, stated with the estimate: 80%; the middle value lies beyond the limit too.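

In this assay compound 1 and compound 3 both stand only as limits, so the step between them cannot be read: the limit of > 26000 nM in this assay, at which 2 of the 3 values shown sit.

Going by these compounds, whether carboxy to ethoxycarbonyl shifts the half-maximal effective concentration at all stays open.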